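The source may report more compounds than this note shows. Statements on the series, on what has been measured and on what is new or still open speak of the compounds shown alone.

Measured compounds: compound 1 `O=C(CSc1nc2ccc(NC(=O)c3ccccc3)cc2s1)NCc1ccc(Cl)cc1` gives 30100 nM; compound 2 `COc1ccc(CNC(=O)CSc2nc3ccc(NC(=O)c4ccccc4)cc3s2)cc1` gives 12700 nM; compound 3 `COc1ccccc1C(=O)Nc1ccc2nc(SCC(=O)NCc3ccc(Cl)cc3)sc2c1` gives 600 nM, all in a functional assay on HepG2 cells (Homo sapiens) for cytotoxicity, read by MTT assay, with a stated time of 48 h; a higher number here means a weaker inhibitor, a lower number a stronger inhibitor.

Within this series compound 3 stands lowest, and both of its steps to the other two are beyond the scatter. From compound 1 to compound 2 the change is methoxy in place of chloro on an aromatic carbon, and the result is a 2.4-fold lower number from compound 1 to compound 2 (0.37 log units; beyond the scatter). The two cores of compound 1 and compound 3 differ by methoxy in place of hydrogen on an aromatic carbon, which gave a 50-fold lower number from compound 1 to compound 3 (1.70 log units; beyond the scatter).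

Compound 4 `COc1ccc(CNC(=O)CSc2nc3ccc(NC(=O)c4ccccc4OC)cc3s2)cc1` has not yet been measured. Among the measured compounds shown here, it differs from compound 3 by methoxy in place of chloro on an aromatic carbon, the same change as the one made from compound 1 to compound 2, at the same place. For the measured compounds named here, the expected step is a 2.0-fold lower number from compound 3 to compound 4 (0.30 log units; within the scatter), which rests on a 2.4-fold lower number from compound 1 to compound 2 (0.37 log units; beyond the scatter) as the only measured instance of this change; a single pair gives little certainty about its size on the other core. Compound 4 is therefore expected to give 300 nM in this assay, estimated to fall between 100 nM and 900 nM.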

Compound 4, half-maximal inhibitory concentration: 2100 nM
Beside the measured number, compound 4's estimate is 7.0-fold (0.85 log units) below it, and the stated range ends below it.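

In this assay, the change from 4-chlorobenzyl to 4-methoxybenzyl gave a 3.5-fold higher number from compound 3 to compound 4 (0.54 log units; beyond the scatter), so on this second core the step ran opposite to the one on the first: the same change on two cores in this assay, a 2.4-fold lower number (0.37 log units; beyond the scatter) from compound 1 to compound 2 and a 3.5-fold higher number (0.54 log units; beyond the scatter) from compound 3 to compound 4, 8.3-fold (0.92 log units) apart, beyond the scatter of two such steps

Methoxy in place of hydrogen kept its direction, with a 6.0-fold lower number from compound 2 to compound 4 (0.78 log units; beyond the scatter), but not its size: the same change on two cores in this assay, a 50-fold lower number (1.70 log units; beyond the scatter) from compound 1 to compound 3 and a 6.0-fold lower number (0.78 log units; beyond the scatter) from compound 2 to compound 4, 8.3-fold (0.92 log units) apart, beyond the scatter of two such steps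

The two changes therefore depend on each other in these four compounds, so a step measured on one core did not predict its counterpart on the other, but this single set of four shows neither why that is so nor whether it holds beyond these compounds.

The compounds shown leave open whether other groups in place of the 4-chlorobenzyl group, such as a 4-fluorobenzyl or a 4-methylbenzyl, would follow compound 3 or compound 4. They also leave open whether an ethoxy or a hydroxyl in place of the methoxy added in compound 3 would show the same dependence on the core.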